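Compound 4: hydroxy for methoxy, expected effect

A few compounds are considered here, and "the series" means these few. Any claim that something is new, unique, unknown or untested is made for them only; others in the source may bear on it.

Measured compounds:
compound 1 `CCN(CC)c1ccc(/C=C2\C(=O)N(C3CCCCC3)C(=S)N2C)c(OC)c1` — 1950 nM
compound 2 `COc1cc(N(C)CCCO)ccc1/C=C1\C(=O)N(C2CCCCC2)C(=S)N1C` — 990 nM
compound 3 `COc1cc(N(C)CCCO)ccc1/C=C1\C(=O)N(c2ccccc2)C(=S)N1C` — 2790 nM

In an assay on isolated protein for inhibition of NADPH oxidase 2 (Homo sapiens), read by chemiluminescence, in the presence of a further agent that is not named here (on this read-out higher numbers stand for weaker inhibition and lower numbers for stronger inhibition), compound 2 carries the lowest of the three numbers. The gap to compound 1 is small: a 2.0-fold lower number from compound 1 to compound 2 (0.29 log units; within the scatter) lies within the scatter, so the two are not ordered. The gap to compound 3 is larger: a 2.8-fold higher number from compound 2 to compound 3 (0.45 log units; beyond the scatter) is a modest step beyond the scatter.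

Compound 4 `CN1C(=S)N(C2CCCCC2)C(=O)/C1=C\c1ccc(N(C)CCCO)cc1O` is not yet measured. Against compound 2 it differs in one place: hydrogen in place of methyl on an oxygen on an aromatic ring; cut one bond further out, the same difference reads methoxy to hydroxy.

Neither measured step touches this oxygen. The step from compound 1 to compound 2 altered the amino group on the aromatic ring; the step from compound 2 to compound 3 altered the substituent on the amide-type nitrogen in the ring. Among the compounds with values here, no measured pair informs the methyl-to-hydrogen change directly. With nothing pointing either way, the expectation for compound 4 is a step of about a 1.0-fold higher number from compound 2 to compound 4 (0.00 log units; within the scatter), that is, none beyond the scatter. Compound 4 is therefore estimated at 1000 nM in this assay, with a range from 400 nM to 2500 nM.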

Compound 4, half-maximal inhibitory concentration: 3390 nM
For compound 4 the middle estimate is 3.4-fold (0.53 log units) below the measured one; the measured number lies above the stated range.
By their numbers in this assay, from the lowest: compounds 2, 1, 3 and 4 (each within the scatter of the next, the first and the last beyond it).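

In this assay the oxygen on the aromatic ring proves to be a position that responds to change: hydrogen in place of methyl gives a 3.4-fold higher number from compound 2 to compound 4 (0.53 log units; beyond the scatter) as a modest loss of inhibition. Within the data shown here, the earlier steps concerned only the amino group and the substituent on the amide-type nitrogen in the ring, so this is the first reading on the methoxy group, and it favours keeping the methyl in the setting of compound 2. No measurement shown here accounts for the change.

One pair cannot say whether an ethoxy group or a longer alkoxy chain on this oxygen would match methoxy or go further. Also open, going by these compounds, is whether the methoxy to hydroxy change costs the same with phenyl on the ring nitrogen, as in compound 3.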